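The compounds below may be only part of what the source reports. "The series", "measured", "known", "first", "only" and "open" are said of these compounds alone.

Measured compounds:
compound 1 `COc1ccc(-c2cc(C(=O)Nc3nc4ccc(Cl)cc4s3)nc3cc(-c4ccccc4)nn23)cc1OC` — 9120 nM
compound 2 `COc1cc(-c2cc(C(=O)Nc3nc4ccc(Cl)cc4s3)nc3cc(-c4ccccc4)nn23)cc(OC)c1OC` — 22400 nM

In a functional assay on HeLa cells (Homo sapiens) for cytotoxicity, read by MTT assay, with a stated time of 48 h (on this read-out higher numbers stand for weaker inhibition and lower numbers for stronger inhibition), compound 1 stands lowest of the two numbers seen so far, and its nearest neighbour is compound 2, which differs from it by one methoxy group and gives the higher number. That step, a 2.5-fold higher number from compound 1 to compound 2 (0.39 log units; beyond the scatter), is the only measured one, and it is modest in size.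

Compound 3 `COc1ccc(-c2cc(C(=O)Nc3nc4ccccc4s3)nc3cc(-c4ccccc4)nn23)cc1OC` differs from compound 1 in a different place: hydrogen in place of chloro on an aromatic carbon. In words, a chloro group is taken off the fused ring system at the amide end and a hydrogen takes its place.

For the measured compounds named here, no measured pair shows what this particular change does. Going by the values given here, the one known step concerns a methoxy group on another ring, so it bears on the present question only in showing that a single small change can move this assay by a modest amount. Without a directly comparable step, the expectation is a small shift, if any, with a slight lean toward a higher number rather than a lower one.

Compound 3 is therefore expected to give about 12000 nM in this assay, within a range of 5000 nM to 30000 nM, corresponding to an expected step of a 1.3-fold higher number from compound 1 to compound 3 (0.12 log units; within the scatter).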

Compound 3, half-maximal inhibitory concentration: 8910 nM
For compound 3 the middle estimate is 1.3-fold (0.13 log units) above the measured one; measured number inside the range.
By their numbers in this assay, from the lowest: compounds 3 and 1 (each within the scatter of the next); then compound 2.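

Swapping the chloro group for hydrogen on the fused ring system at the amide end gives, in this assay, a 1.0-fold lower number from compound 1 to compound 3 (0.01 log units; within the scatter), so the two compounds cannot be told apart on this read-out. For the compounds shown here, the earlier compounds showed only that a single small change elsewhere in the molecule can register, as the added methoxy group did with a 2.5-fold higher number from compound 1 to compound 2 (0.39 log units; beyond the scatter); this result adds that not every single-atom-sized edit does, and that with the 3,4-dimethoxyphenyl-type end of compound 1 held fixed, the 6-chloro-1,3-benzothiazol-2-yl and 1,3-benzothiazol-2-yl forms read alike in this cell assay. Nothing in hand explains why this place tolerates the swap.

Going by these compounds, whether a quite different group at the same aromatic carbon, such as an amine, a carboxylic acid or a methoxy group, would also leave the number within the scatter remains open. On these data alone, it is equally open whether hydrogen in place of chloro would read the same on the core of compound 2, which carries the extra methoxy group.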